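A few compounds are considered here, and "the series" means these few. Any claim that something is new, unique, unknown or untested is made for them only; others in the source may bear on it.

Measured in a functional assay on LOX IMVI cells (Homo sapiens) for cytotoxicity, read by MTT assay, with a stated time of 24 h; a lower number here means a stronger inhibitor, a higher number a weaker inhibitor:

- Compound 1 `COc1cc(-c2nc(-c3ccccc3)[nH]c2-c2ccnc(NCCCNS(=O)(=O)c3ccc(C(F)(F)F)cc3)n2)ccc1F`: 75200 nM
- Compound 2 `COc1cc(-c2nc(-c3ccccc3)[nH]c2-c2ccnc(NCCCNS(=O)(=O)c3cccc(F)c3)n2)ccc1F`: 900 nM

Of these two, compound 1 has the higher number and so is the weaker inhibitor in this assay. Compound 3 `O=S(=O)(NCCCNc1nccc(-c2[nH]c(-c3ccccc3)nc2-c2ccc(F)c(O)c2)n1)c1ccc(C(F)(F)F)cc1` differs from compound 1 by hydrogen in place of methyl on an oxygen on an aromatic ring: methoxy becomes hydroxy, giving a 4-fluoro-3-hydroxyphenyl group. Within the data shown here, the only measured step, an 84-fold lower number from compound 1 to compound 2 (1.92 log units; beyond the scatter), is large, but it lies on the sulfonyl sulfur and not on this oxygen. It shows that one change can move the number far in this pair, yet it says nothing about the size or direction of the present change. With compound 1 at 75200 nM, a modest fall is more likely than a further rise, though this is only a weak expectation. The expected change is a 2.5-fold lower number from compound 1 to compound 3 (0.40 log units; beyond the scatter). For compound 3 the estimated value is 30000 nM, with an expected range of 5000 nM to 100000 nM.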

Compound 3, half-maximal inhibitory concentration: 2450 nM
Beside the measured number, compound 3's estimate is 12-fold (1.09 log units) above it, outside the stated range (below it).
By their numbers in this assay, from the lowest: compound 2; then compound 3; then compound 1.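

In this assay the oxygen on the aromatic ring proves to be a sensitive place: taking off only the methyl, so that 4-fluoro-3-methoxyphenyl becomes 4-fluoro-3-hydroxyphenyl, gives a 31-fold lower number from compound 1 to compound 3 (1.49 log units; beyond the scatter) and counts as large. Earlier, only the group on the sulfonyl sulfur had been seen to move the number, so this is a second place where one change has a large effect, here the loss of a single carbon. Nothing measured here explains why the number falls with this change.

From the compounds shown here alone, it remains open whether an amine in place of the hydroxy, or an ethyl on the same oxygen, would give a similar number. Going by these compounds, it is also open whether the same swap from methoxy to hydroxy would lower the number when the 3-fluorophenyl of compound 2 sits on the sulfonyl sulfur.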